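The source may hold more compounds than are shown below. What is called first, only, known or untested is meant among the compounds shown, and "the series" means these compounds.

Compound 1 `O=c1c2cc([N+](=O)[O-])ccc2n(CCCBr)n1Cc1ccccc1` is the starting point. In an ADME assay on L929 cells (Mus musculus) for cytotoxicity, read by resazurin assay, with a stated time of 48 h (a higher number here means that more compound is tolerated, a lower number that less compound is tolerated), compound 1 gives 25200 nM, the lowest of the two plain numbers here. Compound 2 `COC(=O)Cn1c2ccc([N+](=O)[O-])cc2c(=O)n1Cc1ccccc1` is the nearest: in this assay compound 2 gives 129000 nM, and the step is a 5.1-fold higher number from compound 1 to compound 2 (0.71 log units; beyond the scatter). Compound 3 `CNC(=O)CCCn1c2ccc([N+](=O)[O-])cc2c(=O)n1Cc1ccccc1` gives > 256000 nM in this assay, which is a limit of the assay and not a number. That step reads an at least 10-fold higher number from compound 1 to compound 3 (1.00 log units; beyond the scatter), and between them an at least 1.9-fold higher number from compound 2 to compound 3 (0.29 log units; that floor lies within the scatter), with the limit of > 256000 nM in this assay, at which 1 of the 3 values shown sits, in mind.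

Compound 4 `O=c1c2cc([N+](=O)[O-])ccc2n(CCCO)n1Cc1ccccc1` differs from compound 1 by hydroxy in place of bromo on a saturated chain carbon, three bonds along the chain from an aromatic nitrogen. Both measured steps that replace the bromo-bearing end, one modest and one at least modest, raised the number, so a modest rise in this assay is expected for compound 4 as well, a 3.2-fold higher number from compound 1 to compound 4 (0.50 log units; beyond the scatter). Compound 4 is therefore estimated at 80000 nM, likely between 30000 nM and 250000 nM.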

Compound 4, concentration lethal to 50% of the cells: > 256000 nM
Compound 4 ended at the assay's limit (the forecaster's own chance of this, stated with the estimate: 10%); at least 3.2-fold (0.50 log units) between middle value and limit.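

In this assay, replacing only the bromo at the end of the chain with hydroxy gives an at least 10-fold higher number from compound 1 to compound 4 (1.00 log units; beyond the scatter), so this one change, with the chain left as it is, is enough to reach the assay's limit. Against the ester, the reading is an at least 1.9-fold higher number from compound 2 to compound 4 (0.29 log units; that floor lies within the scatter), so no order between those two can be claimed. The step from compound 3 to compound 4 cannot be read, as both values are limits: the limit of > 256000 nM in this assay, at which 2 of the 4 values shown sit.

Going by these compounds, how far compound 3 and compound 4 lie past that limit stays open. So does whether an amine or a carboxylic acid at the same chain end, or hydroxy on a longer chain, would also reach it.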